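A few compounds are considered here, and "the series" means these few. Any claim that something is new, unique, unknown or untested is made for them only; others in the source may bear on it.

Measured compounds:
Compound 1, `CC(C)n1cc(-c2ccnc3[nH]c(C4CCN(CC(=O)N5CCCC5)CC4)cc23)ccc1=O`, 3.5 uL/min.
Compound 2, `COc1cc(F)ccc1-c1ccnc2[nH]c(C3CCN(CC(=O)N(C)C)CC3)cc12`, 4.9 uL/min.

Within the data shown here, only two compounds have been tested in an ADME assay on cells (Hepatocyte, Homo sapiens) for metabolic stability; on this read-out lower numbers stand for slow clearance and higher numbers for fast clearance. In this assay compound 2 gives 4.9 uL/min, and compound 1 gives 3.5 uL/min. The two numbers sit within the scatter of each other, so neither compound can be said to clear faster or slower than the other; compound 2 simply stands at the same level as compound 1.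

The account now turns to compound 3, `CC(C)n1nc(-c2ccnc3[nH]c(C4CCN(CC(=O)N(C)C)CC4)cc23)ccc1=O`, which has not yet been tested. Compared with compound 2 the change is a group of 10 heavy atoms (7 carbon, 2 nitrogen, 1 oxygen; one six-membered aromatic ring with 2 hetero atoms) in place of a group of 9 heavy atoms (7 carbon, 1 oxygen, 1 fluorine; one six-membered aromatic ring of carbon only), on an aromatic carbon. The rest of the molecule, including the shared core and the dimethyl amide chain, is kept as in compound 2.

Among the measured compounds shown here, no step between measured compounds is available to guide the expectation. Both measured compounds give low numbers in this assay, and compound 1 carries a related six-membered ring with a carbonyl in the same position while giving 3.5 uL/min. Compound 3 is therefore expected to stay at a similar level, with an estimate of 4 uL/min, ranging from 2 uL/min to 8 uL/min. The expected step is a 1.2-fold lower number from compound 2 to compound 3 (0.09 log units; within the scatter), which is not expected to reach beyond the scatter.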

Compound 3, intrinsic clearance in a liver preparation (reported as CLH), per the amount of preparation that the assay uses in the Hepatocyte assay: 2 uL/min
Estimate against measurement, compound 3: 2.0-fold (0.30 log units) above; the measured number falls inside the stated range.
By their numbers in the Hepatocyte assay, from the lowest: compounds 3, 1 and 2 (each within the scatter of the next, the first and the last beyond it).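

Among these compounds, on an aromatic carbon opposite the ring nitrogen, replacing 4-fluoro-2-methoxyphenyl with the six-membered aromatic ring with 2 hetero atoms gives the first step between compounds differing in one place in the Hepatocyte assay: a 2.5-fold lower number from compound 2 to compound 3 (0.39 log units; beyond the scatter), so clearance at this position responds to the group placed there. The same change also moves acid dissociation, since in a physicochemical assay for acid dissociation, compound 2 gives 8 and compound 3 gives 7.6. Acid dissociation is thus the one measured property that shifts together with the clearance number, which makes it a possible but unproven link, resting on a single pair of compounds: the measured acid dissociation constant of compound 2, 8, and of compound 3, 7.6, a number 0.40 log units lower (beyond the scatter)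

The whole group is exchanged in one step, so the compounds shown cannot say which part of it, the ring nitrogens, the carbonyl or the carbon substituent on the ring, carries the shift in either read-out. They also leave open whether a quite different group at this position, such as a morpholine or a carboxylic acid, would move clearance and acid dissociation together or apart.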